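A few compounds are considered here, and "the series" means these few. Any claim that something is new, unique, unknown or untested is made for them only; others in the source may bear on it.

Three compounds share one core. Compound 1 `O=C(Nc1ccc(Oc2ccnc3[nH]ccc23)cc1)c1cc2cccnc2n(-c2ccccc2)c1=O` carries a plain phenyl on the core and a hydrogen on its aromatic nitrogen; in a functional assay on A549 cells (Homo sapiens) for antiproliferative activity, read by MTT assay, with a stated time of 72 h (on this read-out higher numbers stand for weaker inhibition and lower numbers for stronger inhibition), compound 1 gives 360 nM. Compound 3 `Cn1ccc2c(Oc3ccc(NC(=O)c4cc5cccnc5n(-c5ccccc5)c4=O)cc3)ccnc21` differs from compound 1 only by a methyl in place of hydrogen on that aromatic nitrogen, and in this assay compound 3 gives 850 nM, a step of a 2.4-fold higher number from compound 1 to compound 3 (0.37 log units; beyond the scatter). Compound 2 `O=C(Nc1ccc(Oc2ccnc3[nH]ccc23)c(F)c1)c1cc2cccnc2n(-c2ccc(C(F)(F)F)cc2Cl)c1=O` differs from compound 1 in several places; in this assay compound 2 gives 1020 nM. Among the three numbers, compound 3 stands second highest, within the scatter of compound 2 and beyond the scatter of compound 1.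

Compound 4 `Cn1ccc2c(Oc3ccc(NC(=O)c4cc5cccnc5n(-c5ccc(Br)cc5)c4=O)cc3)ccnc21` is compound 3 with bromo in place of hydrogen on an aromatic carbon. For the measured compounds named here, no measured step matches this change: the only single-place step, from compound 1 to compound 3, touched the aromatic nitrogen, not the phenyl. Compound 2, whose phenyl carries chloro and trifluoromethyl, gives a number near that of compound 3, but it also differs elsewhere, so it offers only a loose hint. For compound 4 a step of a 1.1-fold higher number from compound 3 to compound 4 (0.02 log units; within the scatter) is expected, likely no further than the scatter. Compound 4 is estimated to give 900 nM, between 400 nM and 2000 nM.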

Compound 4, half-maximal inhibitory concentration: 680 nM
Compound 4: middle estimate off by 1.3-fold (0.12 log units), on the high side; low and high end bracket the measured number.
By their numbers in this assay, from the lowest: compounds 1, 4, 3 and 2 (each within the scatter of the next, the first and the last beyond it).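

In this assay, going from phenyl to 4-bromophenyl gives a 1.3-fold lower number from compound 3 to compound 4 (0.10 log units; within the scatter) and so stays within the scatter, the first single-place change seen on this aromatic ring. The earlier single-place step touched only the aromatic nitrogen, and compound 2 differs in several places, so neither could show that one bromine atom on this carbon, para to a large group, leaves the number within the scatter of the unsubstituted phenyl. Nothing measured here offers an explanation for this result.

Going by these compounds, whether an amine, a carboxylic acid or a longer chain on the same carbon would also stay within the scatter remains open. So does whether bromo would behave the same way in compound 1, which keeps the hydrogen on the aromatic nitrogen.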